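Hydrazide in place of amine on two adenosine-like scaffolds

A few compounds are considered here, and "the series" means these few. Any claim that something is new, unique, unknown or untested is made for them only; others in the source may bear on it.

Measured so far:
- compound 1, `CN(CCC(=O)NN)C[C@H]1O[C@@H](n2cnc3c(N)ncnc32)[C@H](O)[C@@H]1O`: 1500 nM
- compound 2, `CN(CCCN)C[C@H]1O[C@@H](n2cnc3c(N)ncnc32)[C@H](O)[C@@H]1O`: 500000 nM
- compound 3, `Cc1nc2c(N)ncnc2n1[C@@H]1O[C@H](CN(C)CCN)[C@@H](O)[C@H]1O`: 88000 nM

The three measured compounds were tested in an assay on isolated protein for inhibition of S-adenosylmethionine decarboxylase proenzyme (Homo sapiens); on this read-out lower numbers stand for stronger inhibition and higher numbers for weaker inhibition. In this assay compound 1 gives 1500 nM, compound 2 gives 500000 nM and compound 3 gives 88000 nM.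

Compounds 2 and 1 share one core and differ in a single place: aminocarbamoyl in place of aminomethyl on a saturated chain carbon, two bonds along the chain from an amine nitrogen. That change made a large step, a 330-fold lower number from compound 2 to compound 1 (2.52 log units; beyond the scatter).

Compound 3 is built on a different core than compound 2; the two have the same atoms joined differently, and the difference between the two cores is not broken down here. Compound 3 sits between the other two, with a higher number than compound 1 and a lower number than compound 2.

Compound 4, `Cc1nc2c(N)ncnc2n1[C@@H]1O[C@H](CN(C)CC(=O)NN)[C@@H](O)[C@H]1O`, has not yet been measured. It is related to compound 3 by aminocarbamoyl in place of aminomethyl on a saturated chain carbon bound to an amine nitrogen. Among the compounds with values here, this is the same kind of change as the one from compound 2 to compound 1, but not the same: there the place was a saturated chain carbon two bonds along the chain from an amine nitrogen, here it is a saturated chain carbon bound to an amine nitrogen, so the chain is shorter.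

Because the earlier change gave a 330-fold lower number from compound 2 to compound 1 (2.52 log units; beyond the scatter), a large step in the same direction is expected for compound 4, though the shorter chain makes its size uncertain; the expected step is a 29-fold lower number from compound 3 to compound 4 (1.47 log units; beyond the scatter). Compound 4 is therefore estimated at 3000 nM in this assay, expected to fall between 300 nM and 30000 nM.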

Compound 4, half-maximal inhibitory concentration: 31000 nM
The estimate for compound 4 lay 10-fold (1.01 log units) below the measured number; measured number above the stated range.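

In this assay, aminocarbamoyl in place of aminomethyl on a saturated chain carbon bound to an amine nitrogen gives a 2.8-fold lower number from compound 3 to compound 4 (0.45 log units; beyond the scatter), so the number falls on this core too, as it did on the core of compound 1. The direction of the change therefore carries over in these two pairs, but its size does not, and the two steps stand clearly apart: the same change on two cores in this assay, a 330-fold lower number (2.52 log units; beyond the scatter) from compound 2 to compound 1 and a 2.8-fold lower number (0.45 log units; beyond the scatter) from compound 3 to compound 4, 120-fold (2.07 log units) apart, beyond the scatter of two such steps This does not show that the core alone sets the size of the step, since the two pairs differ in their core and also in their chain length, and the gap cannot be assigned to either difference from these four compounds.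

Left open is what the same change does with the longer chain of compound 1 on the core of compound 3, and with the shorter chain of compound 4 on the core of compound 1, the pairings that would separate the effect of the chain from that of the core. Also open, from the compounds shown here alone, is whether another group at the end of the chain, such as a carboxylic acid or a plain amide, would lower the number on both cores as aminocarbamoyl does.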